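This account rests on a few compounds, and the source may have more. Where it says the series, first, only, none or still open, it means among the compounds named here.

Two compounds define the range so far. Compound 1 `COc1cc(C2=CC3CNCC(C2)C3)cnc1Cl` is the stronger of the pair: in an in vitro assay on SH-SY5Y cells for displacement of a labelled ligand from Neuronal acetylcholine receptor; alpha3/beta4 (Homo sapiens) (a lower number here means a stronger inhibitor, a higher number a weaker inhibitor), compound 1 gives 7 nM. Compound 2 `COc1ccc(Oc2cncc(C3=CC4CNCC(C3)C4)c2)cc1` stands at the high end of the two numbers, and in this assay compound 2 gives 27 nM; the gap to compound 1 lies beyond the usual scatter. The next compound, compound 3 `COc1cncc(C2=CC3CNCC(C2)C3)c1`, has not yet been measured. It differs from compound 2 in one place: methyl in place of 4-methoxyphenyl on an oxygen on an aromatic ring, so the larger group is trimmed back to a methyl on the ring oxygen. Among the measured compounds shown here, no measured pair shows this exact change, so the step can only be judged from what surrounds it. Compound 1 also carries a methyl on an oxygen on an aromatic ring, and because compound 1 gives 7 nM such a group is compatible with a strong result. The step from compound 2 to compound 3 is therefore expected to move toward a lower number, of modest size, a 1.8-fold lower number from compound 2 to compound 3 (0.26 log units; within the scatter). Compound 3 is expected to give 15 nM, with a likely range from 5 nM to 50 nM.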

Compound 3, inhibition constant: 14.3 nM
Beside the measured number, compound 3's estimate is 1.0-fold (0.02 log units) above it; the range from low to high includes it.
By their numbers in this assay, from the lowest: compound 1; then compounds 3 and 2 (each within the scatter of the next).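

In this assay, among the compounds shown here, trimming the group on the ring oxygen gives the first direct reading at this position (a 1.9-fold lower number from compound 2 to compound 3 (0.28 log units; within the scatter)). The 4-methoxyphenyl, with its 8 heavy atoms and its six-membered aromatic ring, gives way to a methyl of 1 heavy atom, yet the step stays within the scatter, so this pair does not separate the two groups on an oxygen on an aromatic ring. The second pair reads a different place, hydrogen in place of chloro on an aromatic carbon (a 2.0-fold higher number from compound 1 to compound 3 (0.31 log units; beyond the scatter)), and this modest step lies beyond the scatter, so in this small set the chloro change registers in the assay while the much larger change on the oxygen does not; nothing given here accounts for either result.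

The compounds shown leave open whether a chain of intermediate length on the ring oxygen, such as ethyl or propyl, or a free hydroxyl in place of the methoxy group, would also stay within the scatter. They also leave open whether the step seen for chloro would hold for fluoro, bromo or an amine on that same aromatic carbon.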